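The source may hold more compounds than are shown below. What is called first, only, known or untested is meant among the compounds shown, and "the series" means these compounds.

Measured so far in a functional assay on the whole organism (Tail, strain ICR) with Mus musculus as the target, in the tail flick test, with a stated time of 120 min, at a dose of 25 umol/kg by the oral route; on this read-out lower numbers stand for a weaker effect and higher numbers for a stronger effect at the one dose given:
compound 1 `N=C(N)NCCC[C@H](NC(=O)CN(c1nc(Cl)nc2[nH]cnc12)C1CC1)C(=O)O` — 17%
compound 2 `CC(C)[C@H](NC(=O)CN(c1nc(Cl)nc2[nH]cnc12)C1CC1)C(=O)OCc1ccccc1` — 27.3%
compound 3 `O=C(CN(c1ncnc2c1ncn2C1CCCCO1)C1CC1)N[C@@H](CO)C(=O)OCc1ccccc1` — 29.2%

Compound 2 stands second highest of the three numbers in this assay. Its nearest neighbour is compound 3, which gives 29.2%, a number that lies within the usual scatter of the value of compound 2, so nothing can be said of an order between those two. The furthest is compound 1, which gives 17%, a number beyond the scatter and lower than that of compound 2; the data give no reason for that gap.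

The step under consideration leads from compound 2 to compound 4 `CSCC[C@H](NC(=O)CN(c1nc(Cl)nc2[nH]cnc12)C1CC1)C(=O)OCc1ccccc1`. The change is 2-(methylsulfanyl)ethyl in place of isopropyl on a saturated chain carbon bound to an amide-type nitrogen and a carbonyl carbon. For the measured compounds named here, no pair of measured compounds shows this same change, and no measured step shares it, so the expectation rests on the value of compound 2 alone. Compound 2 and compound 3 carry the same ester and differ at that chain carbon, and their numbers lie within the scatter of each other; on that basis the expected step of a number 0.7 percentage points higher from compound 2 to compound 4 (within the scatter) is none beyond the scatter. Compound 4 is therefore estimated at 28%, with a range from 14% to 42%.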

Compound 4, a percentage reported as activity, at one dose (the size of the read-out at that dose, not a potency): 31.6%
Compound 4: middle estimate off by 3.6 percentage points, on the low side; the measured number falls inside the stated range.
By their numbers in this assay, from the lowest: compound 1; then compounds 2, 3 and 4 (each within the scatter of the next).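

In this assay the saturated chain carbon bound to an amide-type nitrogen and a carbonyl carbon now has its first step that changes only this place: 2-(methylsulfanyl)ethyl in place of isopropyl gives a number 4.3 percentage points higher from compound 2 to compound 4 (within the scatter) and so shows no separable effect on the read-out. The exchange adds one heavy atom, a sulfur, and one hydrogen-bond acceptor, with no ring, hydrogen-bond donor or net charge added, and at this one dose and time, that change in the side chain cannot be told apart from the usual scatter. No measurement shown here gives a reason for the size of this step.

As far as these compounds go, whether a benzyl group or a 4-aminobutyl chain on that chain carbon would move the read-out beyond the scatter from compound 2 remains open, as does the effect of a methylsulfonyl group in place of 2-(methylsulfanyl)ethyl. Also open, from the compounds shown here alone, is whether the same exchange would give a similar step with a free carboxylic acid in place of the benzyl ester, and how compound 2 and compound 4 would compare at other doses or times.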